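Trading a Methylpiperidinyl for a Hydroxypiperidinyl Group

The source may report more compounds than this note shows. Statements on the series, on what has been measured and on what is new or still open speak of the compounds shown alone.

Of the compounds shown here, three have been measured in an assay on Sf9 cells for inhibition of Leucine-rich repeat serine/threonine-protein kinase 2 (Homo sapiens), read by TR-FRET, with stated times of 30 min and 2 h; on this read-out lower numbers stand for stronger inhibition and higher numbers for weaker inhibition. Compound 1 `O=C(Nc1cccc(Cl)c1)c1cc(C(F)(F)F)ccc1OCc1ccccc1` gives 25.1 nM, compound 3 `O=C(Nc1cccnc1)c1cc(C(F)(F)F)ccc1OCc1ccccc1` gives 12.6 nM, and compound 2 `CN1CCC(c2ccc(OCc3ccccc3)c(C(=O)Nc3ccnnc3)c2)CC1` gives 20 nM. The number for compound 2 sits between the other two: the gap to compound 1 and the gap to compound 3 are both within the scatter, so the three numbers are indistinguishable here. Within the data shown here, the only step among measured compounds, a 2.0-fold lower number from compound 1 to compound 3 (0.30 log units; within the scatter), concerns the group on the amide-type nitrogen and stays within the scatter.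

Compound 4 `O=C(Nc1ccnnc1)c1cc(N2CCC(O)CC2)ccc1OCc1ccccc1` is not yet measured. It differs from compound 2 in one place: 4-hydroxypiperidin-1-yl in place of 1-methylpiperidin-4-yl on an aromatic carbon. Among the measured compounds shown here, no measured step touches this aromatic carbon, so there is no direct precedent for the change; the one step that exists, from compound 1 to compound 3, shows only that a change elsewhere on the shared core left the number essentially unmoved. On that basis a step of no more than the scatter is expected in this assay, in no particular direction, that is no change at the digits printed from compound 2 to compound 4 (within the scatter). Compound 4 is therefore estimated at 20 nM, with a range from 6 nM to 65 nM.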

Compound 4, half-maximal inhibitory concentration: 39.8 nM
For compound 4 the middle estimate is 2.0-fold (0.30 log units) below the measured one; measured number inside the range.
By their numbers in this assay, from the lowest: compounds 3, 2, 1 and 4 (each within the scatter of the next, the first and the last beyond it).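

In this assay, among these compounds, putting 4-hydroxypiperidin-1-yl in place of 1-methylpiperidin-4-yl gives a 2.0-fold higher number from compound 2 to compound 4 (0.30 log units; within the scatter), the first reading at this aromatic carbon, which stands para to the benzyloxy group and meta to the (pyridazin-4-yl)carbamoyl group. The exchange alters more than one feature at once: the ring is now joined to the aromatic carbon through its nitrogen rather than through a ring carbon, the methyl group is gone, and the hydroxyl brings a hydrogen-bond donor that the leaving group lacks, yet the two compounds cannot be told apart in this assay. No outside evidence bears on this result, so the reading stands without an explanation.

The compounds shown leave open what a plain piperidin-1-yl group would give on this aromatic carbon, a comparison that would separate the hydroxyl from the change in how the ring is joined. They also leave open whether a morpholine, a piperazine or a carboxylic acid at the same place would stay as close to compound 2.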